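The source may hold more compounds than are shown below. What is called first, only, known or untested is meant among the compounds shown, and "the series" means these compounds.

Measured in an ADME assay on MT4 cells (Homo sapiens) for inhibition; a lower number here means that less compound is tolerated, a higher number that more compound is tolerated:
- compound 1 `CNC(=O)CCCCn1c(=O)c(C)cn([C@@H]2O[C@H](CO[Si](C)(C)C(C)(C)C)[C@@]3(OS(=O)(=O)C=C3N)[C@H]2O[Si](C)(C)C(C)(C)C)c1=O`: > 250000 nM (a limit)
- compound 2 `CCCn1c(=O)c(C)cn([C@@H]2O[C@H](CO[Si](C)(C)C(C)(C)C)[C@@]3(OS(=O)(=O)C=C3N)[C@H]2O[Si](C)(C)C(C)(C)C)c1=O`: 75000 nM
- compound 3 `Cc1cn([C@@H]2O[C@H](CO[Si](C)(C)C(C)(C)C)[C@@]3(OS(=O)(=O)C=C3N)[C@H]2O[Si](C)(C)C(C)(C)C)c(=O)n(/C=C\CO)c1=O`: 36000 nM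

Only two of the three entries are actual numbers, the third being (the limit of > 250000 nM in this assay, at which 1 of the 3 values shown sits). Compound 3 has the lower of those two numbers, and its nearest neighbour is compound 2, with a 2.1-fold lower number from compound 2 to compound 3 (0.32 log units; beyond the scatter). The two steps that start at the limit, an at least 3.3-fold lower number from compound 1 to compound 2 (0.52 log units; beyond the scatter) and an at least 6.9-fold lower number from compound 1 to compound 3 (0.84 log units; beyond the scatter), are bounds only.

Next in the series is compound 4 `Cc1cn([C@@H]2O[C@H](CO[Si](C)(C)C(C)(C)C)[C@@]3(OS(=O)(=O)C=C3N)[C@H]2O[Si](C)(C)C(C)(C)C)c(=O)n(CC2CO2)c1=O`, in which (oxiran-2-yl)methyl stands in place of 3-hydroxyprop-1-en-1-yl on an aromatic nitrogen: (oxiran-2-yl)methyl in place of 3-hydroxyprop-1-en-1-yl on an aromatic nitrogen. The two have the same atoms, joined differently. Among the compounds with values here, no measured step brings in this three-membered ring, so the closest guide is the other change at the same aromatic nitrogen, a 2.1-fold lower number from compound 2 to compound 3 (0.32 log units; beyond the scatter), which is modest. The larger steps from compound 1 remove a methylcarbamoyl-bearing chain, and neither compound 3 nor compound 4 carries one. In this assay, no change beyond the scatter is therefore expected, and the estimated step is a 1.1-fold lower number from compound 3 to compound 4 (0.05 log units; within the scatter). The estimate for compound 4 is 32000 nM, with an expected range from 12000 nM to 85000 nM.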

Compound 4, half-maximal cytotoxic concentration: 56000 nM
For compound 4 the middle estimate is 1.8-fold (0.24 log units) below the measured one, within the range that was stated.
By their numbers in this assay, from the lowest: compounds 3, 4 and 2 (each within the scatter of the next, the first and the last beyond it). At a limit, above all of these: compound 1.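

In this assay, (oxiran-2-yl)methyl in place of 3-hydroxyprop-1-en-1-yl on the aromatic nitrogen gives a 1.6-fold higher number from compound 3 to compound 4 (0.19 log units; within the scatter), and oxiran-2-yl in place of ethyl on the saturated chain carbon gives a 1.3-fold lower number from compound 2 to compound 4 (0.13 log units; within the scatter), so neither the three-membered ring nor the loss of the hydrogen-bond donor separates compound 4 from the open-chain groups. Compound 4 lies within the scatter of both compound 2 and compound 3, even though a 2.1-fold lower number from compound 2 to compound 3 (0.32 log units; beyond the scatter), so these three groups occupy one narrow band, with compound 1 as the exception to it. Compound 1 stands at a limit, so an at least 4.4-fold lower number from compound 1 to compound 4 (0.64 log units; beyond the scatter) is a bound only and the true size of that step stays unknown: the limit of > 250000 nM in this assay, at which 1 of the 4 values shown sits.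

From the compounds shown here alone, whether the higher number of compound 1 belongs to the longer chain or to its terminal amide stays open, and a plain pentyl chain or a butyl chain ending in a carboxylic acid would separate the two. Also open, going by these compounds, is whether the oxirane behaves differently from other small groups at this nitrogen, such as an azetidine, a 2-methoxyethyl chain or a 2,3-dihydroxypropyl chain.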